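A few compounds are considered here, and "the series" means these few. Any claim that something is new, unique, unknown or untested is made for them only; others in the source may bear on it.

Measured in a functional assay on HCT-116 cells (Homo sapiens), read by MTT assay, with a stated time of 72 h (on this read-out lower numbers stand for stronger inhibition and higher numbers for weaker inhibition), all three values being limits of the assay and not numbers:
- compound 1 `COc1ncnc2c1c(-c1ccccc1)cn2[C@@H]1O[C@H](CO)[C@@H](O)[C@H]1O` gives > 20000 nM
- compound 2 `CSc1ncnc2c1c(-c1ccccc1)cn2[C@@H]1O[C@H](CO)[C@@H](O)[C@H]1O` gives > 20000 nM
- compound 3 `CNc1ncnc2c1c(-c1ccsc1)cn2[C@@H]1O[C@H](CO)[C@@H](O)[C@H]1O` gives > 20000 nM

Compound 3 stands only as a limit, at > 20000 nM. For the measured compounds named here, the series so far offers no number to place it against: the limit of > 20000 nM in this assay, at which 3 of the 3 values shown sit.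

The change under consideration is phenyl in place of thiophen-3-yl on an aromatic carbon, which leads to compound 4 `CNc1ncnc2c1c(-c1ccccc1)cn2[C@@H]1O[C@H](CO)[C@@H](O)[C@H]1O`. In words, this is phenyl in place of thiophen-3-yl on an aromatic carbon, with the rest of compound 3 kept.

Going by the values given here, the only measured step is a step that the two limits leave unreadable from compound 1 to compound 2. It lies elsewhere on the shared core, as methylsulfanyl in place of methoxy, and gives no size to carry over. Among the compounds with values here, no measured pair isolates the exchange of thiophen-3-yl for phenyl. The remaining evidence is indirect: compound 1 and compound 2 already carry the entering phenyl, and neither yields a number in this assay. Compound 3, with thiophen-3-yl, yields none either. No change beyond the scatter, in either direction, is therefore expected.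

The expected step is a number no higher from compound 3 to compound 4 (the limit leaves the size open). For compound 4 the estimate is 20000 nM, with an expected range from 7000 nM to 40000 nM, and a report of only a limit is the likeliest outcome.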

Compound 4, half-maximal inhibitory concentration: > 100000 nM
Compound 4 was reported as a limit (the forecaster's own chance of this, stated with the estimate: 85%); middle value at least 5.0-fold (0.69 log units) away from the limit.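

In this assay compound 4 gives > 100000 nM, a limit of the assay and not a number. For the compounds shown here, compound 1, compound 2 and compound 3 also stand only as limits, and no step from any of them to compound 4 can be read. On these data alone, the size of the exchange of thiophen-3-yl for phenyl, and of the exchanges among methoxy, methylsulfanyl and methylamino, remains open in this assay.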